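The source may report more compounds than this note shows. Statements on the series, on what has been measured and on what is new or still open speak of the compounds shown alone.

Going by the values given here, in a functional assay on PC-3 cells (Homo sapiens) for cytotoxicity, read by MTT assay, with a stated time of 72 h (a higher number here means a weaker inhibitor, a lower number a stronger inhibitor), compound 3 (`COc1ccc(OC)c(/C=C/C(=O)Nc2cc3c(Nc4ccc(F)c(Cl)c4)ncnc3cc2O[C@H]2CCOC2)c1`) gives 8730 nM, the lowest number so far, against compound 1 (`COc1cc(/C=C/C(=O)Nc2cc3c(Nc4ccc(F)c(Cl)c4)ncnc3cc2O[C@H]2CCOC2)cc(OC)c1OC`) at 20500 nM and compound 2 (`N#Cc1ccc(/C=C/C(=O)Nc2cc3c(Nc4ccc(F)c(Cl)c4)ncnc3cc2O[C@H]2CCOC2)cc1`) at 36600 nM. Compound 4 (`O=C(/C=C/c1cc(Br)c(O)c(Br)c1)Nc1cc2c(Nc3ccc(F)c(Cl)c3)ncnc2cc1O[C@H]1CCOC1`) differs from compound 3 by one change, 3,5-dibromo-4-hydroxyphenyl in place of 2,5-dimethoxyphenyl on a double-bonded chain carbon bound to a double-bonded chain carbon. The measured steps at this same place are small: a 2.3-fold lower number from compound 1 to compound 3 (0.37 log units; beyond the scatter) and a 4.2-fold lower number from compound 2 to compound 3 (0.62 log units; beyond the scatter), both modest, and a 1.8-fold higher number from compound 1 to compound 2 (0.25 log units; within the scatter), within the scatter. Among the compounds with values here, no measured compound carries the entering group, so the direction is poorly supported. In this assay, the expected step is a 1.6-fold higher number from compound 3 to compound 4 (0.21 log units; within the scatter), which would not exceed the scatter. The estimate for compound 4 is 14000 nM, with an expected range of 5000 nM to 40000 nM.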

Compound 4, half-maximal inhibitory concentration: 25500 nM
Compound 4: the middle estimate sits 1.8-fold (0.26 log units) below what was measured, within the range that was stated.
By their numbers in this assay, from the lowest: compound 3; then compounds 1, 4 and 2 (each within the scatter of the next).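

In this assay, 3,5-dibromo-4-hydroxyphenyl does not keep the standing of 2,5-dimethoxyphenyl at this place, with a 2.9-fold higher number from compound 3 to compound 4 (0.47 log units; beyond the scatter) as the first step measured for a ring carrying bromine and a hydrogen-bond donor. Against the other two rings the same group shows a 1.4-fold lower number from compound 2 to compound 4 (0.16 log units; within the scatter) and a 1.2-fold higher number from compound 1 to compound 4 (0.09 log units; within the scatter) and separates from neither. Among these four rings, only 2,5-dimethoxyphenyl in compound 3 stands apart from all the others. Open, on these data alone, is whether a ring bearing an amine or a carboxylic acid at this place would move the number beyond that of compound 3. Nothing measured on these compounds accounts for their order.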